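The source may hold more compounds than are shown below. What is called first, only, known or untested is meant among the compounds shown, and "the series" means these compounds.

Compound 1 `CC1(C)[C@@H]2CC[C@@]1(CS(=O)(=O)N1CCN(c3ccccn3)CC1)C(=O)C2` was tested in a functional assay on CHO-K1 cells for antagonist activity at C-X-C chemokine receptor type 3 (Homo sapiens), read by FLIPR and calcium flux; a lower number here means a stronger inhibitor, a higher number a weaker inhibitor. In this assay compound 1 gives > 31600 nM, which is a limit of the assay rather than a measured number. Compound 2 `CC1(C)[C@@H]2CC[C@@]1(CS(=O)(=O)NC1CCN(c3ccc(C(F)(F)F)cn3)CC1)C(=O)C2` carries a trifluoromethyl-bearing pyridine, and in this assay compound 2 gives 15800 nM. Compound 3 `CC1(C)[C@@H]2CC[C@@]1(CS(=O)(=O)N1CCN(c3ccc(C(F)(F)F)nn3)CC1)C(=O)C2` is not yet measured; it differs from compound 1 in that (6-(trifluoromethyl)pyridazin-3-yl in place of pyridin-2-yl on an amine nitrogen in a ring). Because compound 1 stands only at the limit of > 31600 nM in this assay, at which 1 of the 2 values shown sits, the step of an at least 2.1-fold lower number from compound 1 to compound 3 (0.32 log units; beyond the scatter) is expected to reach a measurable value, at most a modest gain. For compound 3 the expected value is 15000 nM, with a range from 5000 nM to 40000 nM.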

Compound 3, half-maximal inhibitory concentration: 5010 nM
The estimate for compound 3 lay 3.0-fold (0.48 log units) above the measured number; the measured number falls inside the stated range.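

In this assay, 6-(trifluoromethyl)pyridazin-3-yl in place of pyridin-2-yl on the amine nitrogen in a ring gives a real measured number on the shared core, with an at least 6.3-fold lower number from compound 1 to compound 3 (0.79 log units; beyond the scatter). The true size of this step stays unknown because compound 1 stands at a limit of the assay: the limit of > 31600 nM in this assay, at which 1 of the 3 values shown sits.

From the compounds shown here alone, this one change both swaps the aromatic ring and adds trifluoromethyl, so the share of each remains unknown. A plain pyridazin-3-yl, or a methyl or chlorine in place of the trifluoromethyl, would help to separate them.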